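The source may hold more compounds than are shown below. What is called first, only, known or untested is meant among the compounds shown, and "the series" means these compounds.

Measured so far in a functional assay on CHO cells with adenosine receptor A1 (Homo sapiens) as the target, read by cAMP accumulation and immunoassay, with a stated time of 6 min, tested at 0.1 uM; on this read-out higher numbers stand for a weaker effect at the one concentration tested and lower numbers for a stronger effect:
Compound 1 `COc1ccc(N2CCN(Cc3csc(N)c3C(=O)c3ccc(Cl)cc3)CC2)cc1` gives 0%.
Compound 2 `Nc1scc(CN2CCN(c3ccc(F)c(F)c3)CC2)c1C(=O)c1ccc(Cl)cc1` gives -34%.
Compound 3 `Nc1scc(CN2CCN(c3cc(F)cc(F)c3)CC2)c1C(=O)c1ccc(Cl)cc1` gives -5%.

Compound 3 stands second highest of the three numbers. Its nearest neighbour is compound 1 (a number 5 percentage points lower from compound 1 to compound 3 (within the scatter)), and compound 2 is the furthest away (a number 29 percentage points higher from compound 2 to compound 3 (beyond the scatter)). The change to compound 4 `Nc1scc(CN2CCN(c3ccc(F)c(Cl)c3)CC2)c1C(=O)c1ccc(Cl)cc1` is 3-chloro-4-fluorophenyl in place of 3,5-difluorophenyl on an amine nitrogen in a ring. The step that bears on it is the one between the two difluorophenyl compounds, in which the shift from 3,4-difluorophenyl to 3,5-difluorophenyl raised the number (a number 29 percentage points higher from compound 2 to compound 3 (beyond the scatter)); the larger step of a number 34 percentage points lower from compound 1 to compound 2 (beyond the scatter) also points the same way. Since compound 4 returns to a 3,4-substitution pattern, the number is expected to fall again by a number 20 percentage points lower from compound 3 to compound 4 (beyond the scatter). Compound 4 is therefore estimated at -25%, with a range from -50% to 0%.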

Compound 4, a percentage reported as activity, at one concentration (the size of the read-out at that concentration, not a potency): -21%
Estimate against measurement, compound 4: 4 percentage points below; low and high end bracket the measured number.
By their numbers in this assay, from the lowest: compound 2; then compound 4; then compounds 3 and 1 (each within the scatter of the next).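

With the 3-chloro-4-fluorophenyl group, the number in this assay moves beyond the scatter in both directions of comparison: down from the 3,5-difluorophenyl compound (a number 16 percentage points lower from compound 3 to compound 4 (beyond the scatter)) and from the 4-methoxyphenyl compound (a number 21 percentage points lower from compound 1 to compound 4 (beyond the scatter)). Chloro in place of fluoro also matters at this position (a number 13 percentage points higher from compound 2 to compound 4 (beyond the scatter)), so the halogen counts as well as where it sits on the ring. No measurement shown accounts for these steps. Going by these compounds, whether a dichlorophenyl group or a pyridine ring on this nitrogen would extend the trend remains open.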